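Series notes: aryl replacement on the carbonyl, compound 3 to 4

The source may report more compounds than this note shows. Statements on the series, on what has been measured and on what is new or still open speak of the compounds shown alone.

Compound 3 `COc1ccc(C(=O)/C=C/c2cc(-c3cc(OC)c(OC)c(OC)c3)n[nH]2)cc1` gives 1% in a functional assay on K562 cells (Homo sapiens) for cytotoxicity, read by sulforhodamine B assay, with a stated time of 48 h, tested at 100 uM (on this read-out lower numbers stand for a stronger effect and higher numbers for a weaker effect at the one concentration tested), the highest of the three numbers; compound 1 `COc1cc(-c2cc(/C=C/C(=O)c3ccc(N)cc3)[nH]n2)cc(OC)c1OC` gives -3%, within the scatter of it, and compound 2 `COc1ccc(C(=O)/C=C/c2cc(-c3cc(OC)c(OC)c(OC)c3)n[nH]2)cc1OC` gives -15%, beyond the scatter. The steps of a number 4 percentage points higher from compound 1 to compound 3 (within the scatter) and a number 16 percentage points higher from compound 2 to compound 3 (beyond the scatter) set where compound 3 stands.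

Compound 4 `COc1cc(-c2cc(/C=C/C(=O)c3ccc(F)c(F)c3)[nH]n2)cc(OC)c1OC` differs from compound 3 by 3,4-difluorophenyl in place of 4-methoxyphenyl on a carbonyl carbon. Going by the values given here, the one measured step on the carbonyl carbon, a number 12 percentage points lower from compound 1 to compound 2 (beyond the scatter), was modest, and the ring step a number 16 percentage points higher from compound 2 to compound 3 (beyond the scatter) was modest as well; no measured step exceeds the scatter by much. The move to compound 4 is therefore expected to shift this assay little, if at all beyond the scatter, a number 3 percentage points lower from compound 3 to compound 4 (within the scatter). Compound 4 is estimated at -2%, range -16% to 12%.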

Compound 4, a percentage reported as activity, at one concentration (the size of the read-out at that concentration, not a potency): -7%
Beside the measured number, compound 4's estimate is 5 percentage points above it; the range from low to high includes it.
By their numbers in this assay, from the lowest: compounds 2, 4, 1 and 3 (each within the scatter of the next, the first and the last beyond it).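

On the carbonyl carbon, 3,4-difluorophenyl gives a reading in this assay that cannot be separated from any of the three other aryl groups: a number 8 percentage points lower from compound 3 to compound 4 (within the scatter), a number 8 percentage points higher from compound 2 to compound 4 (within the scatter) and a number 4 percentage points lower from compound 1 to compound 4 (within the scatter). Compound 4 thus lies within the scatter of both compound 2 and compound 3, although those two lie beyond the scatter of each other, so the position tolerates fluorine substituents on this ring as well as methoxy or amino groups. Nothing available explains these readings.

Still open, from the compounds shown here alone, is whether a carboxylic acid on this aryl ring, or a cyclohexyl group in its place on the carbonyl carbon, would keep this assay in the same range.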